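Swapping a Ring Chloro for Methylsulfonyl in a Weak Series

This account rests on a few compounds, and the source may have more. Where it says the series, first, only, none or still open, it means among the compounds named here.

Within the data shown here, compound 2 `O=C(Nc1ccc(Cl)c(-c2nnc3c(Cl)cccn23)c1)c1ccc(Cl)cc1Cl` is one of two compounds measured in a functional assay on AN3-CA cells (Homo sapiens) for antiproliferative activity, read by MTT assay, with a stated time of 72 h (on this read-out lower numbers stand for stronger inhibition and higher numbers for weaker inhibition), where compound 2 gives 84800 nM, the only plain number in the set. Compound 1 `O=C(Nc1ccc(Cl)c(-c2nnc3c(Cl)cccn23)c1)c1ccc(C(F)(F)F)cc1Cl` reaches only a limit there, > 100000 nM. The evidence at hand is thus a single limit, (the limit of > 100000 nM in this assay, at which 1 of the 2 values shown sits), beside one number. Among the measured compounds shown here, the one measured step, an at least 1.1-fold lower number from compound 1 to compound 2 (0.07 log units; that floor lies within the scatter), is too small to tell anything beyond the scatter. Compound 3 `CS(=O)(=O)c1ccc(C(=O)Nc2ccc(Cl)c(-c3nnc4c(Cl)cccn34)c2)c(Cl)c1` differs from compound 2 by methylsulfonyl in place of chloro on an aromatic carbon. For the measured compounds named here, no measured step involves a methylsulfonyl group; the only comparison on record, a chloro for a trifluoromethyl on an aromatic carbon, stayed within the scatter, so the weak activity of compound 2 is the starting point and no step beyond the scatter is expected in this assay. Compound 3 is therefore estimated at 80000 nM, with a range from 25000 nM to 300000 nM. This estimate means an expected step of a 1.1-fold lower number from compound 2 to compound 3 (0.03 log units; within the scatter), which lies within the scatter. With so little to go on, a reading that ends as a limit is also possible.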

Compound 3, half-maximal inhibitory concentration: > 100000 nM
Compound 3 was reported as a limit; the forecaster's own chance of this, stated with the estimate: 40%; middle value at least 1.2-fold (0.09 log units) from the limit.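

In this assay, the position para to a large group now carries a third group, and methylsulfonyl, with hydrogen-bond acceptors that chloro does not have, brings no readable gain over chloro: the result is an at least 1.1-fold higher number from compound 2 to compound 3 (0.07 log units; that floor lies within the scatter). Compound 3 is reported only as a limit, so that step has a floor and no measured size, and the step between the two limit compounds cannot be read at all. What this adds is breadth rather than a trend: chloro, trifluoromethyl and now methylsulfonyl have all been tried at this one position, none separates from the others beyond the scatter, and the set gathers at a single limit: the limit of > 100000 nM in this assay, at which 2 of the 3 values shown sit.

An amine, a carboxylic acid or a plain methyl at this position remains an open case, and only a plain number there, not another limit, would give a step of readable size. Also open is whether the weak activity depends on this position at all or on the rest of the structure, which stays the same in all the compounds shown.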